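A few compounds are considered here, and "the series" means these few. Any claim that something is new, unique, unknown or untested is made for them only; others in the source may bear on it.

Measured so far in a physicochemical assay for solubility, in phosphate buffer, at pH 6.8; a higher number here means a more soluble compound, a lower number a less soluble compound:
- compound 1 `CCn1c(NC(C)(C)C)nc2ccsc2c1=O`: 3.7 ug/mL
- compound 2 `CCn1c(NC(C)C)nc2c(-c3cncnc3)csc2c1=O`: 18 ug/mL

Compound 1 stands lowest of the two numbers. Compound 1 at 3.7 ug/mL lies below compound 2 at 18 ug/mL, a gap beyond the scatter. For the measured compounds named here, the two compounds do not differ in one place only, so no measured single-change step is available to the series.

Next is compound 3 `CCn1c(NC2CCOCC2)nc2ccsc2c1=O`, which shares its core with compound 1. The change is oxan-4-yl in place of tert-butyl on a nitrogen on an aromatic ring.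

Going by the values given here, with compound 1 at 3.7 ug/mL and no measured step to lean on, the expectation in this assay rests on the structural change alone. A moderate rise beyond the scatter is expected, estimated as a 3.2-fold higher number from compound 1 to compound 3 (0.51 log units; beyond the scatter). For compound 3 the estimated value is 12 ug/mL, with an expected range from 4 ug/mL to 40 ug/mL.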

Compound 3, solubility: 37 ug/mL
For compound 3 the middle estimate is 3.1-fold (0.49 log units) below the measured one, within the range that was stated.
By their numbers in this assay, from the lowest: compound 1; then compound 2; then compound 3.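

In this assay, the series now has its first single-change reading: the swap of tert-butyl for oxan-4-yl on a nitrogen on an aromatic ring gives a 10-fold higher number from compound 1 to compound 3 (1.00 log units; beyond the scatter) with the shared core unchanged. This shows that the group at this position can move the read-out well beyond the scatter, and the incoming group brings one six-membered non-aromatic ring with 1 hetero atom and 1 hydrogen-bond acceptor. Nothing available explains the step or assigns it to any one of those features.

Still open, as far as these compounds go, is whether the ring itself or its oxygen carries the step, which cyclohexyl or piperidin-4-yl at this nitrogen could help separate. A single step also leaves open whether the swap would give a similar step on a core bearing another group, such as the pyrimidin-5-yl of compound 2.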